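A few compounds are considered here, and "the series" means these few. Any claim that something is new, unique, unknown or untested is made for them only; others in the source may bear on it.

Measured in an ADME assay on L6 cells (Rattus norvegicus) for cytotoxicity, read by resazurin assay, with a stated time of 72 h; on this read-out lower numbers stand for stronger inhibition and higher numbers for weaker inhibition:
Compound 1 `OC(c1ccc(Cl)cc1)(c1ccc(C(F)(F)F)cc1)c1cccnc1`: 56400 nM
Compound 2 `CS(=O)(=O)Nc1ccc(C(O)(c2ccc(Cl)cc2)c2cccnc2)cc1`: > 100000 nM (a limit of the assay, not a number)

Within the data shown here, compound 1, at 56400 nM, holds the only true number in this assay so far. Compound 2 reads > 100000 nM, and this is a limit of the assay. Compound 3 `CN(C)c1ccc(C(O)(c2ccc(C(F)(F)F)cc2)c2cccnc2)cc1` keeps the trifluoromethyl group of compound 1 and changes the chlorine-bearing ring instead: dimethylamino in place of chloro on an aromatic carbon, that is, 4-chlorophenyl to 4-(dimethylamino)phenyl. Among the measured compounds shown here, the one measured step, an at least 1.7-fold higher number from compound 1 to compound 2 (0.24 log units; that floor lies within the scatter), exchanges trifluoromethyl for methanesulfonamido, so it touches a different group and bears only indirectly. Its floor lies within the scatter, and it gives no direction for the present change. No step beyond the scatter is therefore expected: the expected change is a 1.3-fold lower number from compound 1 to compound 3 (0.10 log units; within the scatter). The estimate for compound 3 is 45000 nM, with an expected range from 15000 nM to 100000 nM.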

Compound 3, half-maximal inhibitory concentration: 59100 nM
Beside the measured number, compound 3's estimate is 1.3-fold (0.12 log units) below it; measured number inside the range.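

In this assay, among these compounds, putting dimethylamino in place of chloro on the ring gives a 1.0-fold higher number from compound 1 to compound 3 (0.02 log units; within the scatter), the first step here that joins two true numbers. Compound 2 carries a limit of the assay and not a number, so the earlier step offered only a floor: the limit of > 100000 nM in this assay, at which 1 of the 3 values shown sits. At this place, on an aromatic carbon para to a large group, the exchange of 4-chlorophenyl for 4-(dimethylamino)phenyl therefore leaves the read-out within the scatter, with the trifluoromethyl group kept in both compounds.

On these data alone, whether another group at this place, such as a carboxylic acid or a longer chain, would also stay within the scatter remains open. Equally open, as far as these compounds go, is whether dimethylamino would behave the same way with methanesulfonamido in place of trifluoromethyl, as in compound 2.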